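The source may hold more compounds than are shown below. What is called first, only, known or untested is meant among the compounds shown, and "the series" means these compounds.

Measured compounds:

compound 1, `COc1ccccc1N1CCN(CCn2nc(-n3cnc4ccccc43)ccc2=O)CC1`, 33 nM
compound 2, `COc1ccccc1N1CCN(CCCCn2nc(-n3cnc4ccccc43)ccc2=O)CC1`, 1.1 nM
compound 3, `COc1ccccc1N1CCN(CCn2nc(-n3ccnc3)ccc2=O)CC1`, 237 nM

All three were tested in an assay on cell membranes from brain for binding affinity to Adrenergic receptor alpha-1 (Rattus norvegicus), read by radioligand binding; on this read-out higher numbers stand for weaker inhibition and lower numbers for stronger inhibition. Compound 2 gives the lowest number of the three; compound 1 stands nearest to it and compound 3 furthest, both beyond the scatter.

Compound 1 and compound 3 differ in one place: 1H-imidazol-1-yl in place of 1H-benzimidazol-1-yl on an aromatic carbon. This change produced a 7.2-fold higher number from compound 1 to compound 3 (0.86 log units; beyond the scatter), so the smaller ring system costs a modest amount of binding in this assay.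

Compound 2 and compound 1 share most of their structure, but the difference between the two cores is not broken down here.

Compound 4, `COc1ccccc1N1CCN(CCCCn2nc(-n3ccnc3)ccc2=O)CC1`, has not yet been measured. It relates to compound 2 in the same way that compound 3 relates to compound 1: 1H-imidazol-1-yl in place of 1H-benzimidazol-1-yl on an aromatic carbon. The place of the change is the same in both pairs, so this is the same change, made a second time on a different core.

Among the compounds with values here, with only this one earlier example, the expectation for compound 4 rests on the step from compound 1 to compound 3. The step from compound 2 to compound 4 is expected to be about a 7.3-fold higher number from compound 2 to compound 4 (0.86 log units; beyond the scatter), because compound 3 showed a 7.2-fold higher number from compound 1 to compound 3 (0.86 log units; beyond the scatter). Applied to compound 2 with 1.1 nM, this gives an estimated value for compound 4 of 8 nM in this assay, with a likely range from 3 nM to 25 nM, since a second core may not respond identically.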

Compound 4, inhibition constant: 47.5 nM
The estimate for compound 4 lay 5.9-fold (0.77 log units) below the measured number; measured number outside the range, above it.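

Putting 1H-imidazol-1-yl in place of 1H-benzimidazol-1-yl on the core of compound 2 gave a 43-fold higher number from compound 2 to compound 4 (1.64 log units; beyond the scatter) in this assay. On both cores, the change moved the number in the same direction, towards weaker inhibition, but the size of the step did not carry over: the same change on two cores in this assay, a 7.2-fold higher number (0.86 log units; beyond the scatter) from compound 1 to compound 3 and a 43-fold higher number (1.64 log units; beyond the scatter) from compound 2 to compound 4, 6.0-fold (0.78 log units) apart, beyond the scatter of two such steps. In this small series, the earlier step therefore pointed the right way but did not give a dependable size for the second core, and two pairs cannot show why the size differs or predict the step on a third core.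

The compounds shown leave open how other groups on that aromatic carbon, such as an amine or a carboxylic acid, would behave on either core, and whether they too would give steps that differ in size between the cores. Within the data shown here, they also leave open whether a longer chain than the one in compound 2 would make the cost of this same change larger still, or whether the step would shrink again.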